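Indazole Ureas: Swapping a Brominated Ring for an Aza-Ring

The compounds below may be only part of what the source reports. "The series", "measured", "known", "first", "only" and "open" are said of these compounds alone.

Among the measured compounds shown here, compound 1 `O=C(Nc1ccc(-n2ncc3c(Br)cccc32)cc1)Nc1ccc(Cl)c(C(F)(F)F)c1` gives 2000 nM in a functional assay on HepG2 cells (Homo sapiens) for cytotoxicity, read by MTT assay, with a stated time of 72 h (on this read-out lower numbers stand for stronger inhibition and higher numbers for weaker inhibition), the lowest of the three numbers measured so far. Compound 2 `COc1cccc2c1cnn2-c1ccc(NC(=O)Nc2ccc(Cl)c(C(F)(F)F)c2)cc1` gives 4000 nM, and the step of a 2.0-fold higher number from compound 1 to compound 2 (0.30 log units; within the scatter) lies within the scatter. Compound 3 `O=C(Nc1ccc(-n2ncc3c(Cl)cccc32)cc1)Nc1ccc(C(F)(F)F)cc1` gives 6700 nM, a higher number than compound 1 and beyond the scatter. Compound 4 `O=C(Nc1ccc(-n2ncc3cnccc32)cc1)Nc1ccc(Cl)c(C(F)(F)F)c1` differs from compound 1 by a group of 9 heavy atoms (6 carbon, 3 nitrogen; one five-membered aromatic ring with 2 hetero atoms, one six-membered aromatic ring with 1 hetero atom) in place of a group of 10 heavy atoms (7 carbon, 2 nitrogen, 1 bromine; one five-membered aromatic ring with 2 hetero atoms, one six-membered aromatic ring of carbon only), on an aromatic carbon. For the measured compounds named here, only the step from compound 1 to compound 2 bears on this change, since it alters the same part of the molecule, and it was small; no measured step covers a ring nitrogen in place of a ring carbon. Compound 4 is therefore expected to show a 1.8-fold higher number from compound 1 to compound 4 (0.24 log units; within the scatter), a change not beyond the scatter, with an estimated value of 3500 nM and a range from 1200 nM to 10000 nM.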

Compound 4, half-maximal inhibitory concentration: 4000 nM
Compound 4: middle estimate off by 1.1-fold (0.06 log units), on the low side; measured number inside the range.
By their numbers in this assay, from the lowest: compounds 1, 2, 4 and 3 (each within the scatter of the next, the first and the last beyond it).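

In this assay, taking out the 4-bromo-1H-indazol-1-yl group and putting in a group whose six-membered ring holds a hetero atom and no bromine gives a 2.0-fold higher number from compound 1 to compound 4 (0.30 log units; within the scatter), so the two numbers cannot be told apart. At this position, then, the ring itself can be altered, not only its substituent, without a step beyond the scatter. No available evidence accounts for this result. Still open, as far as these compounds go, is whether an amine or a carboxylic acid on this ring would give a step beyond the scatter.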